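Linker exchange on the carboxyphenyl arm, compound 3 to compound 4

This account rests on a few compounds, and the source may have more. Where it says the series, first, only, none or still open, it means among the compounds named here.

Three compounds carry numbers in a functional assay on HEK293 cells for agonist activity at Bile acid receptor (Homo sapiens), read by a luciferase reporter; a higher number here means that more compound is needed for the effect, a lower number that less compound is needed. Compound 1 `Cc1cc(OCc2c(-c3c(Cl)cccc3Cl)noc2C(C)C)nc2ccccc12` gives 878 nM. Compound 2 `CC(C)c1onc(-c2c(Cl)cccc2Cl)c1COc1ccc(N(C)Cc2cccc(C(=O)O)c2)c(C(F)(F)F)n1` gives 6 nM. Compound 3 `CN(Cc1cccc(C(=O)O)c1)c1ccc(OCc2c(-c3c(Cl)cccc3Cl)noc2C2CC2)nc1C(F)(F)F` gives 2 nM, the lowest of the three; its nearest neighbour is compound 2, and the gap to compound 1 is wide, as the two values show. Among the compounds with values here, the one single-point step on record, a 3.0-fold lower number from compound 2 to compound 3 (0.48 log units; beyond the scatter), concerns the small alkyl group on the shared core and not the arm changed here.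

Compound 4 `CC(Oc1cccc(C(=O)O)c1)c1ccc(OCc2c(-c3c(Cl)cccc3Cl)noc2C2CC2)nc1C(F)(F)F` differs from compound 3 only at the arm bearing the carboxyphenyl group: 1-(3-carboxyphenoxy)ethyl in place of (3-carboxybenzyl)(methyl)amino on an aromatic carbon. The carboxylic acid, the aromatic ring and the heavy-atom count are kept, so this is an exchange of the linker and its attachment. Within the data shown here, no measured step bears directly on such an exchange; the step between compound 2 and compound 3 touches a different site, and its modest size gives the only scale for what one change has done. A step of about that size or smaller is therefore expected in this assay, direction uncertain, a somewhat higher number judged a little more likely than a lower one. For compound 4 the expected value is 5 nM, with a range from 1.5 nM to 20 nM. The step this implies, a 2.5-fold higher number from compound 3 to compound 4 (0.40 log units; beyond the scatter), is an estimate only.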

Compound 4, half-maximal effective concentration: 58 nM
For compound 4 the middle estimate is 12-fold (1.06 log units) below the measured one; the measured number lies above the stated range.
By their numbers in this assay, from the lowest: compound 3; then compound 2; then compound 4; then compound 1.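

Within the data shown here, the exchange gives a 29-fold higher number from compound 3 to compound 4 (1.46 log units; beyond the scatter) in this assay and so outweighs a 3.0-fold lower number from compound 2 to compound 3 (0.48 log units; beyond the scatter) at the small alkyl group, making this arm, of the two sites with a step on record, the one where a single change has moved the number more. The two arms match in heavy atoms, hydrogen-bond donors and hydrogen-bond acceptors, and both keep the carboxylic acid and the aromatic ring, so those counts do not account for the step; the arms differ in the linker, which is attached to the ring through nitrogen in compound 3 and through a carbon bearing a methyl group in compound 4, where an oxygen also joins the linker to the phenyl ring. Nothing on hand bears on why the number moved this far.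

The compounds shown leave open which part of the exchange carries the step: the loss of the amine nitrogen, the added phenoxy oxygen or the branching methyl group. An arm such as (3-carboxybenzyl)oxy, or a 1-(3-carboxyphenyl)ethylamino arm that keeps a nitrogen on the ring, would help to separate these parts.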